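This account rests on a few compounds, and the source may have more. Where it says the series, first, only, none or still open, it means among the compounds named here.

Compound 1 `CC1=CC(=O)/C(=C(/C)Nc2ccc3c(Cl)nn(C)c3c2)C(=O)O1` and compound 2 `CCn1nc(Cl)c2ccc(N/C(C)=C3\C(=O)C=C(C)OC3=O)cc21` share a core and differ by methyl in place of hydrogen on a saturated chain carbon bound to an aromatic nitrogen. In an ADME assay on RAW264.7 cells (Mus musculus) for cytotoxicity, read by resazurin assay, with a stated time of 48 h (on this read-out lower numbers stand for higher toxicity in this test and higher numbers for lower toxicity in this test), compound 1 gives only a limit of the test, > 100000 nM. In this assay compound 2 gives 6230 nM. That step, an at least 16-fold lower number from compound 1 to compound 2 (1.20 log units; beyond the scatter), is a large one, though its true size is not fixed because the limit of > 100000 nM in this assay, at which 2 of the 3 values shown sit, holds the starting value. Compound 3 `CC1=CC(=O)/C(=C(/C)Nc2ccc3c(cnn3C)c2)C(=O)O1` has a different core; the difference between the two cores is not broken down here. In this assay compound 3 gives only a limit, > 100000 nM. Compound 4 `CCn1ncc2cc(N/C(C)=C3\C(=O)C=C(C)OC3=O)ccc21` differs from compound 3 by methyl in place of hydrogen on a saturated chain carbon bound to an aromatic nitrogen, the same kind of change as before, at the same place. On that basis compound 4 is expected to sit around 20000 nM in this assay, a step of about an at least 5.0-fold lower number from compound 3 to compound 4 (0.69 log units; beyond the scatter) from compound 3, resting on the move seen in an at least 16-fold lower number from compound 1 to compound 2 (1.20 log units; beyond the scatter).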

Compound 4, half-maximal cytotoxic concentration: > 100000 nM
Compound 4 gave a limit, no number; the forecaster's own chance of this, stated with the estimate: 30%; middle value at least 5.0-fold (0.69 log units) away from the limit.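

No step can be read between compound 3 and compound 4, because both sit at the same limit of the test: the limit of > 100000 nM in this assay, at which 3 of the 4 values shown sit. From the compounds shown here alone, whether methyl in place of hydrogen lowers the number on the core of compound 3, as it does on the core of compound 1, stays open.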